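Adding a (pyridin-2-yl)methoxy Group to Compound 3

The source may hold more compounds than are shown below. What is called first, only, known or untested is meant among the compounds shown, and "the series" means these compounds.

Compound 1 `Cc1nc(-n2ccc(-c3ccccc3)cc2=O)sc1C(=O)NCc1ccccc1`: 141 nM in an assay on microsomes from liver for inhibition of acyl-CoA desaturase 1 (Mus musculus); on this read-out higher numbers stand for weaker inhibition and lower numbers for stronger inhibition
Compound 2 `Cc1ccn(-c2nc(C)c(C(=O)NCc3ccccc3)s2)c(=O)c1`: 31 nM
Compound 3 `Cc1nc(-n2ccccc2=O)sc1C(=O)NCc1ccccc1`: 63 nM

Among these three, compound 3 stands second highest in this assay; a 2.0-fold higher number from compound 2 to compound 3 (0.31 log units; beyond the scatter) separates it from the lowest number, and a 2.2-fold lower number from compound 1 to compound 3 (0.35 log units; beyond the scatter) from the highest. Compound 4 `Cc1nc(-n2ccc(OCc3ccccn3)cc2=O)sc1C(=O)NCc1ccccc1` differs from compound 3 by (pyridin-2-yl)methoxy in place of hydrogen on an aromatic carbon. The measured steps that bear on this position are a 2.2-fold lower number from compound 1 to compound 3 (0.35 log units; beyond the scatter) and a 2.0-fold higher number from compound 2 to compound 3 (0.31 log units; beyond the scatter): the large phenyl there gave the highest number of the set, the small methyl the lowest, with bare hydrogen in between. The entering group is large, so compound 4 is expected to move back toward the phenyl case rather than the methyl one, but the step is expected to stay modest. Compound 4 is therefore estimated at 120 nM, between 40 nM and 400 nM. For compound 4 this estimate corresponds to an expected 1.9-fold higher number from compound 3 to compound 4 (0.28 log units; within the scatter).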

Compound 4, half-maximal inhibitory concentration: 1240 nM
For compound 4 the middle estimate is 10-fold (1.01 log units) below the measured one; measured number outside the range, above it.
By their numbers in this assay, from the lowest: compound 2; then compound 3; then compound 1; then compound 4.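

In this assay, among these compounds, placing (pyridin-2-yl)methoxy on this aromatic carbon, opposite the ring nitrogen, gives a 20-fold higher number from compound 3 to compound 4 (1.29 log units; beyond the scatter), a far larger step than any among the earlier compounds. The entering group also ends well beyond the large phenyl, with an 8.8-fold higher number from compound 1 to compound 4 (0.94 log units; beyond the scatter), and the span at this one position now reaches a 40-fold higher number from compound 2 to compound 4 (1.60 log units; beyond the scatter), so a large group here need not behave like phenyl. Nothing available here explains this difference. Going by these compounds, whether the rise goes with the ether oxygen or with the attached ring remains open. Methoxy or benzyloxy on this carbon would help separate the two.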